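A few compounds are considered here, and "the series" means these few. Any claim that something is new, unique, unknown or untested is made for them only; others in the source may bear on it.

In an ADME assay on HEK293 cells (Homo sapiens) for antiproliferative activity, read by MTT assay (on this read-out higher numbers stand for weaker inhibition and lower numbers for stronger inhibition), the measured compounds read as follows
Compound 1 (`Nc1c(C(=O)NC2CCCC2)oc2nc(-c3ccccc3)cc(C(F)(F)F)c12`) gives 85000 nM
Compound 2 (`CNC(=O)c1oc2nc(-c3cccs3)cc(C(F)(F)F)c2c1N`) gives 75000 nM

Compound 2, at 75000 nM in this assay, stands within the usual scatter of compound 1, so the two values set no order between them. Compound 3 (`Nc1c(C(=O)NC2CCCC2)oc2nc(-c3cccs3)cc(C(F)(F)F)c12`) has not yet been measured. It departs from compound 2 by one structural change (cyclopentyl in place of methyl on an amide-type nitrogen), cyclopentyl in place of methyl on an amide-type nitrogen. For the measured compounds named here, no pair of measured compounds differs in one place only, so the data give no direct measure of what such a change does. In this assay no shift beyond the scatter is therefore expected, in either direction. The expected size of the change, a 1.1-fold higher number from compound 2 to compound 3 (0.03 log units; within the scatter), stays within that scatter. Compound 3 is estimated at 80000 nM (expected range 40000 nM to 150000 nM).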

Compound 3, half-maximal inhibitory concentration: 51000 nM
For compound 3 the middle estimate is 1.6-fold (0.20 log units) above the measured one; the measured number falls inside the stated range.
By their numbers in this assay, from the lowest: compounds 3, 2 and 1 (each within the scatter of the next).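

Two single changes now have a direct measure in this assay. Cyclopentyl in place of methyl on the amide-type nitrogen gives a step that stays within the scatter (a 1.5-fold lower number from compound 2 to compound 3 (0.17 log units; within the scatter)), and so does thiophen-2-yl in place of phenyl on an aromatic carbon (a 1.7-fold lower number from compound 1 to compound 3 (0.22 log units; within the scatter)), so neither change separates its pair of compounds in this assay. Nothing available here accounts for these values.

With a single replacement tested at each place, the compounds shown do not tell whether another group on the amide-type nitrogen, such as a longer chain, a benzyl group or a chain ending in an amine, would move the number beyond the scatter. As far as these compounds go, it also stays open whether a pyridine ring or a furan ring in place of thiophen-2-yl on the aromatic carbon would do so.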